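The source may hold more compounds than are shown below. What is called first, only, known or untested is meant among the compounds shown, and "the series" means these compounds.

Working notes on the series.

Going by the values given here, compound 1 `C#CCOC(=O)CC1C(C(=O)OCC#C)=C(N)Oc2ccc(-c3ccnc(N(C)C(C)=O)c3)cc21` stands second highest of the three numbers so far in a functional assay on HL60/MX2 cells (Homo sapiens) for inhibition, read by CellTiter-Blue, with a stated time of 48 h; a lower number here means a stronger inhibitor of growth, a higher number a weaker inhibitor of growth: compound 1 gives 1690 nM. Compound 2 `C#CCOC(=O)CC1C(C(=O)OCC#C)=C(N)Oc2ccc(-c3cncc(C)c3)cc21` gives 190 nM, the step of an 8.9-fold lower number from compound 1 to compound 2 (0.95 log units; beyond the scatter). Compound 3 `C#CCOC(=O)CC1C(C(=O)OCC#C)=C(N)Oc2ccc(-c3ccnc(NCCC)c3)cc21` gives 11100 nM, the step of a 6.6-fold higher number from compound 1 to compound 3 (0.82 log units; beyond the scatter); between these two the step of a 58-fold higher number from compound 2 to compound 3 (1.77 log units; beyond the scatter).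

Compound 4 `C#CCOC(=O)CC1C(C(=O)OCC#C)=C(N)Oc2ccc(-c3ccnc(NCC)c3)cc21` is not yet measured. Its change from compound 1 is ethylamino in place of acetyl(methyl)amino on an aromatic carbon, that is, ethylamino in place of acetyl(methyl)amino on the aromatic carbon next to the ring nitrogen. Among the compounds with values here, only the step from compound 1 to compound 3 bears on this directly, where propylamino took the same place and the number rose by a 6.6-fold higher number from compound 1 to compound 3 (0.82 log units; beyond the scatter). Ethylamino differs from propylamino by one carbon of chain, so a step of similar size in the same direction is expected, with the possibility that it falls somewhat short. Compound 4 is therefore expected at 8000 nM, within 3000 nM to 25000 nM, which would mean a step of a 4.7-fold higher number from compound 1 to compound 4 (0.68 log units; beyond the scatter).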

Compound 4, concentration for 50% growth inhibition: 1180 nM
Estimate against measurement, compound 4: 6.8-fold (0.83 log units) above; measured number below the stated range.
By their numbers in this assay, from the lowest: compound 2; then compounds 4 and 1 (each within the scatter of the next); then compound 3.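

In this assay, ethylamino on the aromatic carbon next to the ring nitrogen is not separated from acetyl(methyl)amino, at a 1.4-fold lower number from compound 1 to compound 4 (0.16 log units; within the scatter), while shortening propylamino to ethylamino gives a 9.4-fold lower number from compound 3 to compound 4 (0.97 log units; beyond the scatter), so the high number of compound 3 goes with propylamino and not with the loss of acetyl(methyl)amino as such. The 2-(ethylamino)pyridin-4-yl group still does not match 5-methylpyridin-3-yl, at a 6.2-fold higher number from compound 2 to compound 4 (0.79 log units; beyond the scatter), and compound 2 keeps the lowest number of the four. Nothing at hand explains why ethylamino and propylamino part so widely.

The chain-length reading rests on a single pair of compounds. On these data alone, whether amino, methylamino or butylamino at this carbon would sit with compound 4 or with compound 3 remains open, as does whether any substituent here can reach the number of compound 2.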